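Bromo-to-hydrogen step carried onto a second core

The source may report more compounds than this note shows. Statements on the series, on what has been measured and on what is new or still open speak of the compounds shown alone.

Measured in a functional assay on A549 cells (Homo sapiens) for cytotoxicity, read by MTT assay, with a stated time of 72 h; on this read-out lower numbers stand for stronger inhibition and higher numbers for weaker inhibition:
compound 1 `O=C(Nc1ccc(Oc2ccnc3[nH]ccc23)cc1)c1nn(-c2ccc(Br)cc2)ccc1=O` gives 6240 nM
compound 2 `O=C(Nc1ccc(Oc2ccnc3[nH]ccc23)cc1)c1nn(-c2ccccc2)ccc1=O` gives 10500 nM
compound 3 `Cn1ccc2c(Oc3ccc(NC(=O)c4nn(-c5ccc(Br)cc5)ccc4=O)cc3F)ccnc21` gives only a limit of the assay, > 60000 nM

The difference between the core of compound 1 and the core of compound 3 is not broken down here. Compound 1 and compound 2 differ by hydrogen in place of bromo on an aromatic carbon, and in this assay this gives a 1.7-fold higher number from compound 1 to compound 2 (0.23 log units; within the scatter).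

Compound 4 `Cn1ccc2c(Oc3ccc(NC(=O)c4nn(-c5ccccc5)ccc4=O)cc3F)ccnc21` is not yet measured. It differs from compound 3 by hydrogen in place of bromo on an aromatic carbon, the same change as that between compound 1 and compound 2, at the same kind of place. For the measured compounds named here, the one measured instance of this change stayed within the scatter, so no shift in either direction is indicated for it. Compound 3 already sits at the limit of > 60000 nM in this assay, at which 1 of the 3 values shown sits, and a change that left the number close to where it was is expected to leave compound 4 at that limit as well.

Compound 4 is expected to give 100000 nM in this assay, with a range of 40000 nM to 300000 nM. The step that the limit leaves unreadable from compound 3 to compound 4 is expected to stay within the scatter.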

Compound 4, half-maximal inhibitory concentration: > 60000 nM
Compound 4: no number, only a limit; the forecaster's own chance of this, stated with the estimate: 85%; the middle value is on the limit's open side.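

In this assay, compound 3 and compound 4 both give a limit of the assay rather than a number, so no step can be read between them. Both stand at the same limit: the limit of > 60000 nM in this assay, at which 2 of the 4 values shown sit.

The compounds shown leave open whether 4-bromophenyl to phenyl on the core of compound 3 matches a 1.7-fold higher number from compound 1 to compound 2 (0.23 log units; within the scatter) on the core of compound 1.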